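The source may hold more compounds than are shown below. What is called first, only, known or untested is meant among the compounds shown, and "the series" means these compounds.

Measured in an assay on isolated protein for inhibition of Nitric oxide synthase, inducible (Homo sapiens), with a stated time of 30 min, tested at 1 mM; on this read-out lower numbers stand for less inhibition and higher numbers for more inhibition at the one concentration tested (going by the name of the read-out):
- compound 1, `COc1ccc(N)c(C2=NN(C(=O)C3CC3)CC2)c1`: 19.9%
- compound 2, `COc1ccc(N)c(C2=NN(C(=O)C3CCC3)CC2)c1`: 1.91%
- compound 3, `COc1ccc(N)c(C2=NN(C(=O)C3CCCC3)CC2)c1`: 1.85%

Compound 1 stands highest of the three numbers. Its step to compound 2 is a number 18 percentage points lower from compound 1 to compound 2 (beyond the scatter) and its step to compound 3 is a number 18.1 percentage points lower from compound 1 to compound 3 (beyond the scatter), both beyond the scatter, while the step of a number 0.1 percentage points lower from compound 2 to compound 3 (within the scatter) lies within it. Every one of these steps changes the ring on the carbonyl carbon; none of them touches the aromatic ring.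

Compound 4, `Nc1ccccc1C1=NN(C(=O)C2CC2)CC1`, differs from compound 1 in exactly that untested place: hydrogen in place of methoxy on an aromatic carbon. Among the measured compounds shown here, no measured step bears on this change, so the three compounds give no direction for it. For the measured compounds named here, the only guide is that compound 1 itself sits at a low level of the read-out, which leaves limited room in either direction. Compound 4 is therefore expected to stay near compound 1, with a step of a number 4.9 percentage points lower from compound 1 to compound 4 (within the scatter) that may well fall within the scatter. The estimate for compound 4 in this assay is 15%, within a range of 2% to 35%.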

Compound 4, a percentage reported as inhibition, at one concentration (the size of the read-out at that concentration, not a potency): 14.8%
Compound 4: the middle estimate sits 0.2 percentage points above what was measured; low and high end bracket the measured number.
By their numbers in this assay, from the lowest: compounds 3 and 2 (each within the scatter of the next); then compounds 4 and 1 (each within the scatter of the next).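

In this assay, hydrogen in place of methoxy on an aromatic carbon gives a number 5.1 percentage points lower from compound 1 to compound 4 (within the scatter) and so, unlike the steps among compounds 1 to 3, tests the aromatic ring. Within this assay and at this one concentration, the methoxy group can therefore be removed without a shift beyond the scatter. Replacing the cyclopropyl ring on the carbonyl carbon with cyclobutyl, by contrast, gives a number 18 percentage points lower from compound 1 to compound 2 (beyond the scatter) and remains the larger change among these compounds. No measurement at hand bears on the reason for this result.

The compounds shown leave open how a chlorine atom, a hydroxyl group or an ethoxy group would read at this place. They also leave open whether removing the methoxy group would give a similar result with cyclobutyl or cyclopentyl on the carbonyl carbon.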